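Three Chalcone-Type Compounds, One Unmeasured Methoxy Analogue

A few compounds are considered here, and "the series" means these few. Any claim that something is new, unique, unknown or untested is made for them only; others in the source may bear on it.

Compound 1 `COc1ccc(CCC(=O)c2cccc(O)c2)cc1` and compound 3 `COc1ccc(CCC(=O)c2cccc(O)c2)c(OC)c1` share a core and differ by one change, (methoxy in place of hydrogen on an aromatic carbon). In an ADME assay on RAW264.7 cells (Mus musculus) for cytotoxicity, read by MTT assay, with a stated time of 24 h, tested at 2.5 ug/mL (on this read-out lower numbers stand for a stronger effect and higher numbers for a weaker effect at the one concentration tested), compound 1 gives 97.1% and compound 3 gives 88.5%, a step of a number 8.6 percentage points lower from compound 1 to compound 3 (within the scatter). Compound 2 `COc1ccc(/C=C/C(=O)c2ccc(OC)c(OC)c2)cc1` has a different core; how its core differs from that of compound 1 is not broken down here. In this assay compound 2 gives 93.1%. Compound 4 `COc1ccc(/C=C/C(=O)c2ccc(OC)c(OC)c2)cc1OC` is not yet measured and differs from compound 2 by methoxy in place of hydrogen on an aromatic carbon. For the measured compounds named here, this is the same kind of change as the one from compound 1 to compound 3, though not the same: in compound 3 the incoming group sits ortho to a large group and meta to a methoxy group, whereas in compound 4 it sits ortho to a methoxy group and meta to a large group. Because the earlier step of a number 8.6 percentage points lower from compound 1 to compound 3 (within the scatter) stayed within the scatter, the step in this assay from compound 2 to compound 4 is expected to be of similar size, a number 5.1 percentage points lower from compound 2 to compound 4 (within the scatter). Compound 4 is therefore estimated to give 88%, expected between 76% and 98%.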

Compound 4, a percentage reported as activity, at one concentration (the size of the read-out at that concentration, not a potency): 91.9%
Beside the measured number, compound 4's estimate is 3.9 percentage points below it; the range from low to high includes it.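

Placed on the second core, methoxy in place of hydrogen on an aromatic carbon gives, in this assay, a number 1.2 percentage points lower from compound 2 to compound 4 (within the scatter). Set side by side, the two steps do not differ, so on these two cores the change carries over as far as this read-out can tell: the same change on two cores in this assay, a number 8.6 percentage points lower (within the scatter) from compound 1 to compound 3 and a number 1.2 percentage points lower (within the scatter) from compound 2 to compound 4, 7.4 percentage points apart, within the scatter of two such steps. This does not show that methoxy has any real effect here, since each step on its own lies within the scatter, and two pairs of compounds at a single concentration say nothing about other cores or about what happens at other concentrations.

The compounds shown leave open how an amine, a carboxylic acid or a longer chain on that aromatic carbon would read in this assay. They also leave open whether any replacement at this place would give a step beyond the scatter, which is what a clear test of transfer between cores would need.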